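This account rests on a few compounds, and the source may have more. Where it says the series, first, only, none or still open, it means among the compounds named here.

In an assay on HepG2 cells for activation of nuclear factor erythroid 2-related factor 2 (Homo sapiens), read by a luciferase reporter, with a stated time of 5 h (on this read-out lower numbers stand for an effect already at smaller amounts and higher numbers for an effect only at larger amounts of compound), three close relatives of one stilbene-type scaffold have been examined. Compound 1 `COc1ccccc1/C=C/c1ccccc1F` gives 3100 nM in this assay. Compound 2 `COc1cccc(/C=C/c2ccccc2F)c1` gives 3800 nM in this assay, and compound 3 `Fc1ccccc1/C=C/c1ccccc1F` gives 4300 nM in this assay. All three numbers lie within the usual scatter of one another, so no order among them can be claimed.

One change is seen once among the measured compounds: methoxy in place of fluoro on an aromatic carbon. In this assay it made a step of a 1.4-fold lower number from compound 3 to compound 1 (0.14 log units; within the scatter), a step that does not rise above the scatter. Compound 2 and compound 3 share the same core as far as their fluoro-bearing ring goes, but how their two cores differ is not broken down here.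

Compound 4 `COc1cccc(/C=C/c2ccccc2OC)c1` is not yet measured. It arises from compound 2 by methoxy in place of fluoro on an aromatic carbon. Among the compounds with values here, this is the same kind of change as the one from compound 3 to compound 1, though the two place descriptions differ: in compound 3 the site is ortho to a group of 9 heavy atoms, in compound 2 it is ortho to a large group. Because the earlier step of a 1.4-fold lower number from compound 3 to compound 1 (0.14 log units; within the scatter) stayed within the scatter, a step of about a 1.4-fold lower number from compound 2 to compound 4 (0.13 log units; within the scatter) is expected for compound 4 in this assay, resting on compound 2 at 3800 nM. Compound 4 is therefore estimated at 2800 nM, with a likely range from 1300 nM to 6000 nM.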

Compound 4, half-maximal effective concentration: 4400 nM
Estimate against measurement, compound 4: 1.6-fold (0.20 log units) below; measured number inside the range.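

In this assay, methoxy in place of fluoro on an aromatic carbon, ortho to a large group, gave a step of a 1.2-fold higher number from compound 2 to compound 4 (0.06 log units; within the scatter), so this second reading of the change also stays inside the usual scatter. Set beside the first reading, the two steps point in opposite directions on paper, yet they cannot be told apart: the same change on two cores in this assay, a 1.4-fold lower number (0.14 log units; within the scatter) from compound 3 to compound 1 and a 1.2-fold higher number (0.06 log units; within the scatter) from compound 2 to compound 4, 1.6-fold (0.21 log units) apart, within the scatter of two such steps. This shows that, on these two cores, the exchange of fluoro for methoxy leaves the number within the scatter, and that the two cores give no sign of treating the change differently; it does not show that the step has a direction or a size of its own, and two cores are too few to support a rule for the whole series.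

The compounds shown carry only fluoro and methoxy on their aromatic rings, all with numbers close together, so it remains open whether an amine, a carboxylic acid or a longer chain at the same place would produce a step that rises above the scatter. As far as these compounds go, it also remains open whether the exchange of fluoro for methoxy would stay this small on a core other than these two.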